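Dropping the Acetoxy Group from a Brominated Furanone

A few compounds are considered here, and "the series" means these few. Any claim that something is new, unique, unknown or untested is made for them only; others in the source may bear on it.

In this study compound 1 `CCC[C@@H](OC(C)=O)C1=C(Br)C(=C(Br)Br)OC1=O` was entered in a functional assay on A-431 cells (Homo sapiens) for cytotoxicity (a lower number here means that less compound is needed, a higher number that more compound is needed for the effect), yet for compound 1 the record shows "not determined" (no result reported). Compound 2 `CCC[C@@H](OC(C)=O)C1=C(Br)[C@@](OC)(C(Br)Br)OC1=O` likewise shows "not determined" (no result reported) in this assay. For compound 3 `CCCCC1=C(Br)/C(=C/Br)OC1=O` the entry in this assay is a limit of the assay rather than a number, > 20 ug/mL. Compound 1 therefore stands without a number of its own; of the three entries, one sits at a limit, as the limit of > 20 ug/mL in this assay, at which 1 of the 3 values shown sits, records, and the other carries no number. Compound 4 `CCCCC1=C(Br)C(=C(Br)Br)OC1=O` has not yet been measured in this assay. It differs from compound 1 by hydrogen in place of acetoxy on a saturated chain carbon bound to a double-bonded ring carbon and a saturated chain carbon. Since compound 1 has no number, no size or direction of step in this assay can be set, and none beyond the scatter is claimed. The author expects compound 4 to give about 25 ug/mL in this assay, within 8 ug/mL to 80 ug/mL, with a limit rather than a number being quite possible.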

Compound 4, concentration for half-maximal effect: 10.5 ug/mL
For compound 4 the middle estimate is 2.4-fold (0.38 log units) above the measured one; measured number inside the range.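

No step can be read between compound 1 and compound 4: compound 1 carries no number to set against the value of compound 4, 10.5 ug/mL. The compounds shown leave open what replacing acetoxy with hydrogen does in this assay, in size or direction.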